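The source may hold more compounds than are shown below. What is called first, only, known or untested is meant among the compounds shown, and "the series" means these compounds.

In a functional assay (aorta) with Oryctolagus cuniculus as the target (a higher number here means weaker binding, a lower number tighter binding), compound 1 (`COc1cc(C(C)=O)ccc1OCCCN1CCC(C(c2ccccc2)c2ccc(F)cc2)CC1`) gives 6.31 nM, and compound 2 (`COc1cc(C(C)=O)ccc1OCCCN1CCC(C(C(N)=O)(c2ccc(F)cc2)c2ccc(F)cc2)CC1`) gives 25.1 nM. Compound 3 (`COc1cc(C#N)ccc1OCCCN1CCC(C(c2ccc(F)cc2)c2ccc(F)cc2)CC1`) gives 2 nM, the lowest number of the three, and both other compounds lie beyond the scatter from it. Compound 4 (`CC(C)(C)c1ccc(OCCCN2CCC(C(c3ccc(F)cc3)c3ccc(F)cc3)CC2)cc1`) differs from compound 3 in one place: 4-(tert-butyl)phenyl in place of 4-cyano-2-methoxyphenyl on an oxygen on a saturated carbon. Going by the values given here, no measured pair isolates this change, so any expectation for it remains loose. Compound 3 already sits at the low end with 2 nM, so a rise is more likely than a further drop. In this assay, the expected change is a moderate rise beyond the scatter, estimated as an 8.0-fold higher number from compound 3 to compound 4 (0.90 log units; beyond the scatter). For compound 4 the estimated value is 16 nM, with an expected range from 4 nM to 60 nM.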

Compound 4, dissociation constant: 1 nM
For compound 4 the middle estimate is 16-fold (1.20 log units) above the measured one; the measured number lies below the stated range.
By their numbers in this assay, from the lowest: compounds 4 and 3 (each within the scatter of the next); then compound 1; then compound 2.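

In this assay the group on this oxygen can change from 4-cyano-2-methoxyphenyl to 4-(tert-butyl)phenyl with a 2.0-fold lower number from compound 3 to compound 4 (0.30 log units; within the scatter) and the number stays low. For this pair, a low number therefore needs neither the nitrile nor the methoxy, and the group's hydrogen-bond acceptors can go with them. Nothing at hand explains this tolerance.

Still open, on these data alone, is whether a carboxylic acid or an amine in place of the tert-butyl would keep the number low. Also open, as far as these compounds go, is whether the same exchange holds on the core of compound 2.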